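The source may hold more compounds than are shown below. What is called first, only, known or untested is meant among the compounds shown, and "the series" means these compounds.

Measured so far in a functional assay on HepG2 cells (Homo sapiens) for inhibition, read by MTT assay, with a stated time of 48 h; on this read-out lower numbers stand for stronger inhibition of growth and higher numbers for weaker inhibition of growth
compound 1 `Cn1cc(C2CC(c3ccc(F)cc3)=NN2C(=O)c2cccnc2)c2cc(Br)ccc21` gives 480 nM
compound 2 `COc1ccc2c(c1)c(C1CC(c3ccccc3)=NN1C(=O)c1cccnc1)cn2C` gives 5110 nM
compound 3 `COc1cccc(C2=NN(C(=O)c3cccnc3)C(c3cn(C)c4ccc(OC)cc34)C2)c1` gives 910 nM

Compound 3 at 910 nM lies within the scatter of compound 1 and far under compound 2 at 5110 nM on these three numbers. The next structure is compound 4 `COc1cccc(C2=NN(C(=O)c3ccc(C)nc3)C(c3cn(C)c4ccc(OC)cc34)C2)c1`, which differs from compound 3 by methyl in place of hydrogen on an aromatic carbon and turns pyridin-3-yl into 6-methylpyridin-3-yl. In words, this is methyl in place of hydrogen on an aromatic carbon.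

The series holds one measured step in a single place, a 5.6-fold lower number from compound 2 to compound 3 (0.75 log units; beyond the scatter) and that step is methoxy in place of hydrogen on an aromatic carbon. It involves a different group on a different ring, so it bears on the present change only loosely. Its size gives a rough idea of how far one small substituent can move the number in this series, but it gives no direction here. For the measured compounds named here, no measured step touches the pyridin-3-yl group, so the estimate stays anchored on compound 3 at 910 nM and the range is kept wide. The expected step is a 1.1-fold lower number from compound 3 to compound 4 (0.06 log units; within the scatter) and no change beyond the scatter is expected. For compound 4 the estimated value is 800 nM with an expected range of 300 nM to 2500 nM around it.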

Compound 4, concentration for 50% growth inhibition: 29 nM
Compound 4: the middle estimate sits 28-fold (1.44 log units) above what was measured, outside the stated range (below it).
By their numbers in this assay, from the lowest: compound 4; then compounds 1 and 3 (each within the scatter of the next); then compound 2.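

In this assay, for the compounds shown here, the step of a 31-fold lower number from compound 3 to compound 4 (1.50 log units; beyond the scatter) shows that the pyridin-3-yl group, unchanged across the earlier compounds, carries a position where the number responds strongly: the change adds only a methyl, 1 heavy atom with no ring and no net charge, on an aromatic carbon next to the ring nitrogen. Going by these compounds alone, that step is large, while the only earlier single-place step, a 5.6-fold lower number from compound 2 to compound 3 (0.75 log units; beyond the scatter) on a different ring, is modest, so the largest shift so far comes from the smallest kind of addition on the acyl side. Nothing available on the compounds accounts for this shift, and its cause remains unassigned.

The compounds shown leave open whether the shift belongs to methyl itself or to any substituent at this carbon, which an ethyl, a chlorine or an amine there would begin to separate. They also leave open whether 6-methylpyridin-3-yl gives a step of similar size on other members of the series, such as the core of compound 1, where the pyridin-3-yl group is still unsubstituted.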